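Sulfone aryl variation in the shared core series

A few compounds are considered here, and "the series" means these few. Any claim that something is new, unique, unknown or untested is made for them only; others in the source may bear on it.

Measured compounds:
compound 1, `CC1CCN(c2c(S(=O)(=O)c3ccc(Cl)cc3)cnc3ccc(F)cc23)CC1`, 80%
compound 2, `CC1CCN(c2c(S(=O)(=O)c3ccccc3)cnc3ccc(F)cc23)CC1`, 40%
compound 3, `Cc1ccc(S(=O)(=O)c2cnc3ccc(F)cc3c2N2CCC(C)CC2)cc1Cl`, 91%

Values are from an assay on isolated protein for displacement of a labelled ligand from metabotropic glutamate receptor 5 (Homo sapiens), with a stated time of 60 min, tested at 1 uM; a higher number here means more inhibition at the concentration tested (going by the name of the read-out), a lower number less inhibition. Compound 3 stands highest of the three in this assay; compound 1 is nearest to it, and compound 2 is furthest, both gaps beyond the scatter. The step of a number 11 percentage points higher from compound 1 to compound 3 (beyond the scatter) is modest, the step of a number 51 percentage points higher from compound 2 to compound 3 (beyond the scatter) is large, and removing the chloro group, a number 40 percentage points lower from compound 1 to compound 2 (beyond the scatter), costs heavily.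

Compound 4, `CC1CCN(c2c(S(=O)(=O)c3ccc(Cl)c(Cl)c3)cnc3ccc(F)cc23)CC1`, is not yet measured. It differs from compound 3 by chloro in place of methyl on an aromatic carbon. Among the measured compounds shown here, no measured step swaps chloro for methyl at that place; the steps from compound 1 and compound 2 to compound 3 show only that the number in this assay is higher with a substituted ring on the sulfonyl sulfur, and that the number is higher with chloro than with hydrogen where the two have been measured. Compound 3 is already near the top of the scale, so a change within the scatter is expected, or a small rise at most, giving a number 3 percentage points lower from compound 3 to compound 4 (within the scatter) as the expected step. Compound 4 is therefore estimated at 88%, with a range from 75% to 97%.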

Compound 4, a percentage reported as inhibition, at one concentration (the size of the read-out at that concentration, not a potency): 91%
The estimate for compound 4 lay 3 percentage points below the measured number, and the stated range covers the measured number.
By their numbers in this assay, from the lowest: compound 2; then compound 1; then compounds 3 and 4 (each within the scatter of the next).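

In this assay, chloro in place of methyl at this place, ortho to a chloro group and para to a large group, gives no change at the digits printed from compound 3 to compound 4 (within the scatter), so the 3-chloro-4-methylphenyl and 3,4-dichlorophenyl groups cannot be told apart by this read-out. The 3,4-dichlorophenyl group also holds the gain over the unsubstituted phenyl, with a number 51 percentage points higher from compound 2 to compound 4 (beyond the scatter), and adding chloro in place of hydrogen to the 4-chlorophenyl group gives a number 11 percentage points higher from compound 1 to compound 4 (beyond the scatter). Nothing at hand explains why methyl and chloro read alike here.

A reading at a single concentration leaves open whether compound 3 and compound 4 would still match in a full potency measurement. Also open, on these data alone, is what a methoxy group, a nitrile or an amine would give at this place on the ring.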